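The source may report more compounds than this note shows. Statements on the series, on what has been measured and on what is new or still open speak of the compounds shown alone.

Compound 1 `CS(=O)(=O)c1ccc(-c2nc(SCCCOC(=O)/C=C/c3ccc(O)c(O)c3)nn2-c2ccc(Br)cc2)cc1` gives 13100 nM in a functional assay on B16-F10 cells (Mus musculus) for antiproliferative activity, read by MTT assay, with a stated time of 72 h; a lower number here means a stronger inhibitor, a higher number a weaker inhibitor. Compound 2 `CS(=O)(=O)c1ccc(-c2nc(SCCCOC(=O)/C=C/c3ccc(O)c(O)c3)nn2-c2ccc(F)cc2)cc1` gives 10400 nM in this assay. Compound 3 `COc1cc(/C=C/C(=O)OCCSc2nc(-c3ccc(S(C)(=O)=O)cc3)n(-c3ccc(Br)cc3)n2)ccc1OC(C)=O` gives 12400 nM in this assay.

Compound 2 differs from compound 1 by fluoro in place of bromo on an aromatic carbon, and that change made a step of a 1.3-fold lower number from compound 1 to compound 2 (0.10 log units; within the scatter), so the two values lie within the scatter of each other. Compound 3 carries a different core from compound 1; the difference between the two cores is not broken down here, and the values of compound 3 and compound 1 also lie within the scatter of each other. Compound 4 `COc1cc(/C=C/C(=O)OCCSc2nc(-c3ccc(S(C)(=O)=O)cc3)n(-c3ccc(F)cc3)n2)ccc1OC(C)=O` has not yet been measured. It differs from compound 3 by fluoro in place of bromo on an aromatic carbon, the same change as that from compound 1 to compound 2, made at the same kind of place. Among the measured compounds shown here, the only guide to its effect in this assay is the earlier step of a 1.3-fold lower number from compound 1 to compound 2 (0.10 log units; within the scatter), which stayed within the scatter. Compound 4 is therefore expected to show a step of about a 1.2-fold lower number from compound 3 to compound 4 (0.09 log units; within the scatter), an expectation that rests on the size of a 1.3-fold lower number from compound 1 to compound 2 (0.10 log units; within the scatter). The estimate for compound 4 in this assay is 10000 nM, expected to fall between 5000 nM and 20000 nM.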

Compound 4, half-maximal inhibitory concentration: 11200 nM
Compound 4: middle estimate off by 1.1-fold (0.05 log units), on the low side; the range from low to high includes it.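

In this assay, replacing 4-bromophenyl with 4-fluorophenyl on the core of compound 3 gave a step of a 1.1-fold lower number from compound 3 to compound 4 (0.04 log units; within the scatter), and this step agrees with the one seen for the same change on the core of compound 1: the same change on two cores in this assay, a 1.3-fold lower number (0.10 log units; within the scatter) from compound 1 to compound 2 and a 1.1-fold lower number (0.04 log units; within the scatter) from compound 3 to compound 4, 1.1-fold (0.06 log units) apart, within the scatter of two such steps. On these two cores, then, the change carries over as a step too small to be told from the scatter, and the choice of core made no visible difference to it. This does not show that fluoro and bromo differ in their effect on this read-out, and two pairs whose steps both stay within the scatter cannot show whether a change with a larger step would carry over in the same way.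

The compounds shown hold only bromo or fluoro at this place, so it remains open whether chloro, methoxy, an amine or a carboxylic acid there would move the number beyond the scatter. Also open, going by these compounds, is whether a longer chain linking the sulfur to the ester would do so.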